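Methyl on a Phenol Oxygen Across Two Isoquinoline Series

The compounds below may be only part of what the source reports. "The series", "measured", "known", "first", "only" and "open" are said of these compounds alone.

Measured compounds:
compound 1 `COc1ccc(-c2cc3ccccc3c(-c3ccc(O)cc3)n2)cc1`: 1220 nM
compound 2 `COc1ccc(-c2cc3ccccc3c(-c3ccc(OC)cc3)n2)cc1`: 850 nM
compound 3 `COc1cc(OC)cc(-c2cc3ccccc3c(-c3cccc(O)c3)n2)c1`: 760 nM

In a functional assay on T47D cells (Homo sapiens) for cytotoxicity, read by CCK-8 assay and cell counting, with a stated time of 72 h (a lower number here means a stronger inhibitor, a higher number a weaker inhibitor), compound 1 gives 1220 nM. Compound 2 carries methyl in place of hydrogen on an oxygen on an aromatic ring, and this change gave a 1.4-fold lower number from compound 1 to compound 2 (0.16 log units; within the scatter). Compound 3 gives 760 nM in this assay; the difference between the core of compound 3 and that of compound 1 is not broken down here. Among the measured compounds shown here, compound 4 `COc1cc(OC)cc(-c2cc3ccccc3c(-c3cccc(OC)c3)n2)c1` is the not yet measured partner of compound 3 and carries methyl in place of hydrogen on an oxygen on an aromatic ring, the same change as the one from compound 1 to compound 2, made at a place described in the same words. Because the earlier step gave a 1.4-fold lower number from compound 1 to compound 2 (0.16 log units; within the scatter), compound 4 is expected to show a step of about a 1.4-fold lower number from compound 3 to compound 4 (0.14 log units; within the scatter) in this assay. Compound 4 is therefore estimated at 550 nM, likely between 250 nM and 1200 nM.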

Compound 4, half-maximal inhibitory concentration: 1120 nM
Compound 4: the middle estimate sits 2.0-fold (0.31 log units) below what was measured; measured number inside the range.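

In this assay, changing hydroxy to methoxy gives a 1.5-fold higher number from compound 3 to compound 4 (0.17 log units; within the scatter), so on this core the step cannot be told apart from the noise of repeated measurements. The earlier step points the other way, but the two steps do not differ by more than that noise, so this is no true reversal between the cores: the same change on two cores in this assay, a 1.4-fold lower number (0.16 log units; within the scatter) from compound 1 to compound 2 and a 1.5-fold higher number (0.17 log units; within the scatter) from compound 3 to compound 4, 2.1-fold (0.33 log units) apart, within the scatter of two such steps

The two pairs therefore show that the change behaved alike within the scatter on these two cores, but they do not show that it would do so on any other core.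

As far as these compounds go, what stays open is how a longer chain on that oxygen, such as ethyl, would behave. From the compounds shown here alone, an amine in place of the hydroxy is equally open.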